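Rhodanine amide series: benzylamide variation, cytotoxicity

This account rests on a few compounds, and the source may have more. Where it says the series, first, only, none or still open, it means among the compounds named here.

Measured compounds:
- compound 1, `O=C(CN1C(=O)/C(=C/c2ccc(-c3ccc(Cl)cc3)o2)SC1=S)NCc1ccc(C(F)(F)F)cc1`: 155000 nM
- compound 2, `O=C(CN1C(=O)/C(=C/c2ccc(-c3ccc(Cl)cc3)o2)SC1=S)NCc1ccccc1Cl`: 64000 nM

Going by the values given here, in a functional assay on K562 cells (Homo sapiens) for cytotoxicity, read by MTT assay, with a stated time of 72 h (on this read-out higher numbers stand for weaker inhibition and lower numbers for stronger inhibition), compound 2 gives the lowest of the two numbers so far; the only neighbour is compound 1, whose number is higher by a 2.4-fold lower number from compound 1 to compound 2 (0.38 log units; beyond the scatter). That single step, 2-chlorophenyl in place of 4-(trifluoromethyl)phenyl on a saturated chain carbon bound to an amide-type nitrogen, is modest but beyond the scatter.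

Compound 3, `Cc1cccc(CNC(=O)CN2C(=O)/C(=C/c3ccc(-c4ccc(Cl)cc4)o3)SC2=S)c1`, differs from compound 2 by 3-methylphenyl in place of 2-chlorophenyl on a saturated chain carbon bound to an amide-type nitrogen. Among the compounds with values here, no measured step covers this exact swap; the one step known at the same place, from compound 1 to compound 2, shows that the group on this carbon can move the number by a modest amount. With nothing that points to a direction for 3-methylphenyl, the expectation is a step of a 1.3-fold higher number from compound 2 to compound 3 (0.10 log units; within the scatter), which is within the scatter, and compound 3 is estimated at 80000 nM in this assay, with a range from 35000 nM to 180000 nM.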

Compound 3, half-maximal inhibitory concentration: 48000 nM
Estimate against measurement, compound 3: 1.7-fold (0.22 log units) above; the range from low to high includes it.
By their numbers in this assay, from the lowest: compounds 3 and 2 (each within the scatter of the next); then compound 1.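

In this assay, exchanging 2-chlorophenyl for 3-methylphenyl gives a 1.3-fold lower number from compound 2 to compound 3 (0.12 log units; within the scatter), so at equal heavy-atom count, these two groups on the saturated chain carbon bound to the amide-type nitrogen are not told apart, even though chlorine gives way to carbon. The second step against the 4-(trifluoromethyl)phenyl group, a 3.2-fold lower number from compound 1 to compound 3 (0.51 log units; beyond the scatter), shows that the gap seen earlier was not peculiar to 2-chlorophenyl: compound 1 now lies beyond the scatter from both other compounds, while those two stay together. No measurement bearing on the origin of these steps is available.

The three aryl groups differ in both the substituent and its place on the ring, so the compounds shown cannot say which of the two sets compound 1 apart. Also open, going by these compounds, is how the number would respond to a carboxylic acid or an amine on the ring, a pyridine ring in place of the phenyl ring, or a longer chain in place of the benzyl carbon.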